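This account rests on a few compounds, and the source may have more. Where it says the series, first, only, none or still open, it means among the compounds named here.

Measured in a functional assay on PC-3 cells (Homo sapiens) for antiproliferative activity, read by MTT assay, with a stated time of 48 h; on this read-out higher numbers stand for weaker inhibition and lower numbers for stronger inhibition:
- Compound 1 `COc1ccc(CN(C(=O)CSc2nc3ccccc3s2)c2cc(OC)c(OC)c(OC)c2)cc1[N+](=O)[O-]`: 26500 nM
- Compound 2 `COc1ccc(CN(C(=O)CSc2nc3ccccc3s2)c2cc(OC)c(OC)c(OC)c2)cc1F`: 20100 nM
- Compound 3 `COc1ccc(CN(C(=O)CSc2nc3ccccc3s2)c2cc(OC)c(OC)c(OC)c2)cc1Br`: 16000 nM

Compound 3 has the lowest number, but it cannot be separated from the other two: the steps are a 1.3-fold lower number from compound 2 to compound 3 (0.10 log units; within the scatter) and a 1.7-fold lower number from compound 1 to compound 3 (0.22 log units; within the scatter). The remaining step is a 1.3-fold lower number from compound 1 to compound 2 (0.12 log units; within the scatter).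

Compound 4 `COc1cc(N(Cc2ccc(Br)cc2)C(=O)CSc2nc3ccccc3s2)cc(OC)c1OC` is unmeasured. It differs from compound 3 as follows: 4-bromophenyl in place of 3-bromo-4-methoxyphenyl on a saturated chain carbon bound to an amide-type nitrogen. This places 4-bromophenyl in place of 3-bromo-4-methoxyphenyl on a saturated chain carbon bound to an amide-type nitrogen.

Among the compounds with values here, no measured compound carries that 4-bromophenyl group, so these steps bear on it only indirectly. All three stayed within the scatter, so no step beyond the scatter is expected. The expected step is a 1.1-fold higher number from compound 3 to compound 4 (0.03 log units; within the scatter). For compound 4 the estimated value is 17000 nM, with an expected range of 7000 nM to 40000 nM.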

Compound 4, half-maximal inhibitory concentration: > 80000 nM
Compound 4: a limit, no number; the forecaster's own chance of this, stated with the estimate: 10%; middle value at least 4.7-fold (0.67 log units) away from the limit.
By their numbers in this assay, from the lowest: compounds 3, 2 and 1 (each within the scatter of the next). At a limit, above all of these: compound 4.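

In this assay compound 4 gives only a limit, > 80000 nM, and not a number. Exchanging nitro, fluoro and bromo left the numbers within the scatter, but this change goes beyond it: an at least 5.0-fold higher number from compound 3 to compound 4 (0.69 log units; beyond the scatter), an at least 3.9-fold higher number from compound 2 to compound 4 (0.59 log units; beyond the scatter) and an at least 3.0-fold higher number from compound 1 to compound 4 (0.47 log units; beyond the scatter). So this position on the saturated chain carbon is not indifferent to every change of the aromatic group.

The 4-bromophenyl group differs from 3-bromo-4-methoxyphenyl both in the methoxy and in where the bromine sits, and the compounds shown do not separate these two differences. On these data alone, what a 3-bromophenyl or a 4-methoxyphenyl group would give here stays open.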